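From trifluoromethyl to chloro on a weak inhibitor

A few compounds are considered here, and "the series" means these few. Any claim that something is new, unique, unknown or untested is made for them only; others in the source may bear on it.

Measured in a functional assay on the whole organism for inhibition, with Scenedesmus acutus as the target, with a stated time of 20 min; a lower number here means a stronger inhibitor, a higher number a weaker inhibitor:
Compound 1 `O=c1c2c(sn1-c1ccc(C(F)(F)F)cc1)CCCC2`: 74100 nM
Compound 2 `CC(C)OC(=O)c1cc(N2C(=O)C3=C(CCCC3)S2(=O)=O)ccc1Cl`: 832 nM
Compound 3 `O=C1C2=C(CCCC2)S(=O)(=O)N1c1cc(OC2CCCC2)c(Cl)cc1F`: 1020 nM

Of these three, compound 1 has the highest number in this assay and is the weakest inhibitor. Compound 2 and compound 3 both have far lower numbers, beyond the scatter, and they lie within the scatter of each other.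

Compound 4 `O=c1c2c(sn1-c1ccc(Cl)cc1)CCCC2` has not yet been measured. It keeps the core of compound 1 and carries chloro in place of trifluoromethyl on an aromatic carbon, para to a large group (chloro in place of trifluoromethyl on an aromatic carbon). No step in a single place has been measured among these compounds, so the data offer no direct guide to this exchange. Compound 2 and compound 3 differ from compound 1 in more than one place and cannot isolate it.

The expectation therefore rests on compound 1 alone, at 74100 nM. No step beyond the scatter is expected in this assay, and the estimate is a 1.3-fold lower number from compound 1 to compound 4 (0.13 log units; within the scatter). Compound 4 is expected to give about 55000 nM, with an estimated range from 18000 nM to 150000 nM.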

Compound 4, half-maximal inhibitory concentration: 20400 nM
Beside the measured number, compound 4's estimate is 2.7-fold (0.43 log units) above it, and the stated range covers the measured number.
By their numbers in this assay, from the lowest: compounds 2 and 3 (each within the scatter of the next); then compound 4; then compound 1.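

In this assay, chloro in place of trifluoromethyl on an aromatic carbon, para to a large group, gives a 3.6-fold lower number from compound 1 to compound 4 (0.56 log units; beyond the scatter) and is the only step among these compounds that changes a single place. It shows that the number in this assay responds to the group at this position on the core of compound 1: replacing a group of four heavy atoms with a single chlorine moves the result beyond the scatter, although the step is modest and compound 4 still gives 20400 nM as a weak inhibitor. No accompanying measurement accounts for the size or direction of this step, so the data describe the change without explaining it.

The compounds shown leave open how other groups at this position, such as methoxy, a nitrile or an amine, would compare with chloro and trifluoromethyl on the same core. They also leave open whether the same exchange would give a step of similar size and direction on the cores of compound 2 and compound 3, which carry different substituents.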